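Alkyl versus arylalkyl ether on a shared core

This account rests on a few compounds, and the source may have more. Where it says the series, first, only, none or still open, it means among the compounds named here.

Compound 1 `CCCCCCCCOc1ccc2c(Cl)ccnc2c1` in a functional assay on HepG2 cells (Homo sapiens) for cytotoxicity, read by MTT assay, with a stated time of 48 h (on this read-out higher numbers stand for weaker inhibition and lower numbers for stronger inhibition), gives 2640 nM. Going by the values given here, compound 2 `Clc1ccnc2cc(OCc3ccccc3)ccc12` in this assay gives 2680 nM; the two numbers lie within the scatter of each other, so compound 1 stands level with compound 2 on the numbers so far. Compound 3 `Clc1ccnc2cc(OCCc3ccccc3)ccc12` carries phenyl in place of hexyl on a saturated chain carbon, two bonds along the chain from an oxygen on an aromatic ring. Among the compounds with values here, no step between measured compounds is at hand, and the two measured ethers already sit at one level, so no shift beyond the scatter is expected from compound 1 to compound 3. Compound 3 is expected at 2600 nM, between 1300 nM and 5200 nM. The estimate corresponds to an expected step of a 1.0-fold lower number from compound 1 to compound 3 (0.01 log units; within the scatter).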

Compound 3, half-maximal inhibitory concentration: 3310 nM
Compound 3: the middle estimate sits 1.3-fold (0.10 log units) below what was measured; low and high end bracket the measured number.
By their numbers in this assay, from the lowest: compounds 1, 2 and 3 (each within the scatter of the next).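

In this assay, phenyl in place of hexyl on a saturated chain carbon, two bonds along the chain from an oxygen on an aromatic ring, gives a 1.3-fold higher number from compound 1 to compound 3 (0.10 log units; within the scatter) and so stays within the scatter. Going by these compounds alone, this is the first readable step at this position, and it shows that an aromatic ring at the chain end and a saturated chain extension stand level here. Within the data shown here, nothing measured so far offers an explanation for this level result.

From the compounds shown here alone, whether an amine or a carboxylic acid at the chain end would hold this level remains open. Going by these compounds, the effect of replacing the chlorine on the shared core is also open.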